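An Aryl Swap on a Compound at the Assay Limit

The source may hold more compounds than are shown below. What is called first, only, known or untested is meant among the compounds shown, and "the series" means these compounds.

Compound 1 `O=C1O/C(=C\Cn2cc(-c3cc(F)cc(F)c3)nn2)C(OCc2ccccc2)=C1OCc1ccccc1` was tested in a functional assay on HepG2 cells (Homo sapiens) for antiproliferative activity, read by MTT assay, with a stated time of 72 h; on this read-out higher numbers stand for weaker inhibition and lower numbers for stronger inhibition. In this assay compound 1 gives > 100000 nM, which is a limit of the assay rather than a number: the limit of > 100000 nM in this assay, at which 1 of the 3 values shown sits. Two companions built on a different core carry actual numbers. Compound 2 `O=C1O[C@H]([C@@H](O)Cn2cc(CNS(=O)(=O)c3ccc(Cl)cc3F)nn2)C(OCc2ccccc2)=C1OCc1ccccc1` gives 25500 nM in this assay, and compound 3 `Cc1ccc(-c2cn(C[C@H](O)[C@H]3OC(=O)C(OCc4ccccc4)=C3OCc3ccccc3)nn2)cc1` gives 8770 nM. Neither of these differs from compound 1 in a single place, so their values only show where they sit, not what any one change does.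

Compound 4 `COc1ccccc1-c1cn(C/C=C2\OC(=O)C(OCc3ccccc3)=C2OCc2ccccc2)nn1` has not yet been measured in this assay. It differs from compound 1 by 2-methoxyphenyl in place of 3,5-difluorophenyl on an aromatic carbon. Within the data shown here, with compound 1 sitting at the limit, no measured step tells how a change of this kind acts, and the companions offer no single-point comparison. The step from compound 1 to compound 4 is expected to be a number no higher from compound 1 to compound 4 (the limit leaves the size open), most likely nothing beyond the scatter. Compound 4 is therefore estimated at 100000 nM, with a range from 30000 nM to 300000 nM, and a fair chance that only a limit is reported once more.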

Compound 4, half-maximal inhibitory concentration: > 100000 nM
Compound 4 was reported as a limit; the forecaster's own chance of this, stated with the estimate: 60%; the middle value lies on the limit itself.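

Compound 1 and compound 4 are both reported only as limits, so swapping 3,5-difluorophenyl for 2-methoxyphenyl gives no readable step: the limit of > 100000 nM in this assay, at which 2 of the 4 values shown sit. The compounds shown leave open how any aryl group acts on this shared core; none with that core carries an actual number.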